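Cell Tolerance of Four Related Nucleoside Analogues

The source may hold more compounds than are shown below. What is called first, only, known or untested is meant among the compounds shown, and "the series" means these compounds.

Measured so far in an ADME assay on Vero 76 cells (Chlorocebus sabaeus) for cytotoxicity, read by neutral red uptake; a lower number here means that less compound is tolerated, a higher number that more compound is tolerated:
compound 1 `CC(C)(O)[C@@H](Nc1nc(Cl)nc2c1ncn2[C@H]1[C@H](O)[C@H](O)[C@]2(CO)C[C@H]12)C1CC1` — > 100000 nM
compound 2 `NCCNC(=O)[C@@]12C[C@@H]1[C@@H](n1cnc3c(NC(C4CC4)C4CC4)nc(Cl)nc31)[C@H](O)[C@@H]2O` — 50000 nM
compound 3 `OC[C@H]1O[C@@H](n2cnc3c(NC(C4CCC4)C4CCC4)nc(Cl)nc32)[C@H](O)[C@@H]1O` — 27000 nM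

Compound 1 gives only a limit of this assay, > 100000 nM (the limit of > 100000 nM in this assay, at which 1 of the 3 values shown sits). Compound 2 gives 50000 nM in this assay. Compound 3 gives 27000 nM in this assay, and that value lies within the scatter of the value of compound 2, so no order between compounds 2 and 3 can be read from them. Compound 1 thus stands at the limit, the one point among the three where no number was obtained, while compounds 2 and 3 each gave a number. Going by the values given here, no pair of measured compounds differs in only one place, so no measured step is available to guide a change.

Compound 4 `OC[C@@]12C[C@@H]1[C@@H](n1cnc3c(NCc4ccccc4)nc(Cl)nc31)[C@H](O)[C@@H]2O` is the next compound to be tested in this assay. It differs from compound 1 in one place: benzyl in place of 1-cyclopropyl-2-hydroxy-2-methylpropyl on a nitrogen on an aromatic ring. Among the compounds with values here, with no measured step of this kind to draw on, the change is expected to move compound 4 toward a number rather than a limit, and the expected step is an at least 1.6-fold lower number from compound 1 to compound 4 (0.22 log units; that floor lies within the scatter). Compound 4 is estimated at 60000 nM in this assay, with a range from 20000 nM to 120000 nM.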

Compound 4, half-maximal cytotoxic concentration: > 100000 nM
Compound 4 gave a limit, no number; the forecaster's own chance of this, stated with the estimate: 35%; at least 1.6-fold (0.22 log units) between middle value and limit.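

In this assay compound 4 gives > 100000 nM, which is a limit and not a number. No step can be read from compound 1 to compound 4, because both compounds rest at a limit: the limit of > 100000 nM in this assay, at which 2 of the 4 values shown sit.

The compounds shown leave open whether benzyl and 1-cyclopropyl-2-hydroxy-2-methylpropyl on that nitrogen differ at all in how much compound the cells tolerate.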